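This account rests on a few compounds, and the source may have more. Where it says the series, first, only, none or still open, it means among the compounds named here.

Measured compounds:
Compound 1, `NS(=O)(=O)c1cccc(-c2nc(C(c3ccc(F)cc3)c3ccc(F)cc3)sc2CC(=O)O)c1`: 55%
Compound 2, `O=C(O)Cc1sc(C(c2ccccc2)c2ccccc2)nc1-c1ccccc1`: 80%

Both compounds were characterised in an in vitro functional assay on HEK285-7 cells for antagonist activity at prostaglandin D2 receptor 2 (Homo sapiens), read by BRET and beta-arrestin recruitment; on this read-out higher numbers stand for larger maximal responses and lower numbers for smaller maximal responses. Compound 1 gives 55% in this assay, the lower of the two numbers, while compound 2 gives 80%, and that gap lies beyond the usual scatter of repeated measurements. Going by the values given here, the two compounds differ from each other in more than one place, so no single step between them can be drawn; only their two values are available.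

Compound 3, `CN(C)c1cc(-c2nc(C(c3ccc(F)cc3)c3ccc(F)cc3)sc2CC(=O)O)ccn1`, has not yet been measured. It differs from compound 1 by 2-(dimethylamino)pyridin-4-yl in place of 3-sulfamoylphenyl on an aromatic carbon. Among the compounds with values here, no measured pair shows what such an exchange does on the shared core, so the size and the direction of the step can only be judged roughly. With compound 1 at 55% and compound 2 at 80% marking the range seen so far, a small change is expected, most likely not beyond the scatter. Compound 3 is estimated to reach 65% in this assay, within 40% to 90%. The expected step of a number 10 percentage points higher from compound 1 to compound 3 (within the scatter) is modest and uncertain in direction.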

Compound 3, largest response reached (reported as efficacy), in percent of the reference or control that the assay uses: 80%
Compound 3: middle estimate off by 15 percentage points, on the low side, and the stated range covers the measured number.
By their numbers in this assay, from the lowest: compound 1; then compounds 2 and 3 (each within the scatter of the next).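

In this assay, going by these compounds alone, putting 2-(dimethylamino)pyridin-4-yl in place of 3-sulfamoylphenyl gives a number 25 percentage points higher from compound 1 to compound 3 (beyond the scatter), the first step that can be read as a change in one place. It shows that the largest response reached on the shared core depends on the group carried by this aromatic carbon, next to the ring nitrogen and next to the ring atom that bears the carboxymethyl group. The exchange alters several things at once, replacing a ring of carbon only that carries a hydrogen-bond donor with a ring holding one hetero atom and no donor, and nothing available here ties the step to any one of these differences or explains it.

The compounds shown leave open whether the ring hetero atom, the dimethylamino group or the loss of the sulfamoyl group accounts for the step, which a 3-(dimethylamino)phenyl or an unsubstituted pyridin-4-yl group at this place would help to separate. They also leave open how a morpholine or a primary amine in place of the dimethylamino group would read in this assay.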